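Ring acetoxy on compound 3: expected outcome

This account rests on a few compounds, and the source may have more. Where it says the series, first, only, none or still open, it means among the compounds named here.

Measured so far in a functional assay on A-431 cells (Homo sapiens) for cytotoxicity, read by sulforhodamine B assay, with a stated time of 72 h; a lower number here means that less compound is needed, a higher number that more compound is needed for the effect
compound 1 `CCCC[C@H](OC(C)=O)[C@@H](O)[C@H](O)[C@@H]1OC(=O)C=C[C@@H]1OC(C)=O` gives 4.5 ug/mL
compound 2 `CCCC[C@@H](/C=C\[C@@H]1OC(=O)C[C@@H](OC)[C@@H]1O)OC(C)=O` gives > 20 ug/mL as a limit, not a number
compound 3 `CCCC[C@H](OC(C)=O)[C@@H](OC(C)=O)[C@H](OC(C)=O)[C@H]1CC=CC(=O)O1` gives 6.5 ug/mL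

Compound 3 (6.5 ug/mL) stands within the scatter of compound 1 (4.5 ug/mL), and the two cannot be ordered in this assay. Compound 2 reports only a limit (> 20 ug/mL). Compound 4 `CCCC[C@H](OC(C)=O)[C@@H](OC(C)=O)[C@H](OC(C)=O)[C@@H]1OC(=O)C=C[C@@H]1OC(C)=O` comes from compound 3 by acetoxy in place of hydrogen on a saturated ring carbon, next to the ring atom that bears a large group (acetoxy in place of hydrogen on a saturated ring carbon). Compound 1, which also carries an acetoxy on its ring, gives a number (4.5 ug/mL), so no step beyond the scatter is expected. The expected step is small (a 1.3-fold lower number from compound 3 to compound 4 (0.11 log units; within the scatter)). The estimate for compound 4 is 5 ug/mL (expected range 1.8 ug/mL to 14 ug/mL).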

Compound 4, concentration for half-maximal effect: 2.6 ug/mL
Compound 4: middle estimate off by 1.9-fold (0.28 log units), on the high side; the measured number falls inside the stated range.
By their numbers in this assay, from the lowest: compounds 4, 1 and 3 (each within the scatter of the next, the first and the last beyond it). At a limit, above all of these: compound 2.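

In this assay acetoxy in place of hydrogen on a saturated ring carbon, next to the ring atom that bears a large group, gives a 2.5-fold lower number from compound 3 to compound 4 (0.40 log units; beyond the scatter) and this modest step is the only one in the series that can be read. The position therefore accepts acetoxy, and the change goes with a lower number rather than a loss of the effect. Nothing measured here gives a cause for the step.

From the compounds shown here alone, whether an amine, a carboxylic acid or a longer ester chain at this ring carbon would give a similar step stays open. Going by these compounds, whether the step carries over to other members is also open.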